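A few compounds are considered here, and "the series" means these few. Any claim that something is new, unique, unknown or untested is made for them only; others in the source may bear on it.

Compound 1 `CCOC(=O)N1CCC(N2CCC[C@@H](NC(=O)c3ccc(C)cc3)C2)CC1` was examined in a functional assay on CHO cells for agonist activity at muscarinic acetylcholine receptor M5 (Rattus norvegicus); on this read-out lower numbers stand for an effect already at smaller amounts and higher numbers for an effect only at larger amounts of compound. In this assay compound 1 reaches only the limit of > 10000 nM, which is a boundary of the method and not a number. Compound 3 `CCOC(=O)N1CCC(N2CCC[C@@H](NC(=O)c3cccs3)C2)CC1` differs from compound 1 by a thiophen-2-yl in place of 4-methylphenyl on a carbonyl carbon, and compound 3 likewise stops at the limit of > 10000 nM. The step that the two limits leave unreadable from compound 1 to compound 3 therefore cannot be read in size or direction, since both of its ends sit at the limit of > 10000 nM in this assay, at which 2 of the 3 values shown sit. Compound 2 `CCOC(=O)N1CCC(NCCNC(=O)c2ccccc2C)CC1`, of a different build, gives the limit of > 30000 nM in this assay, the boundary described by the limit of > 30000 nM in this assay, at which 1 of the 3 values shown sits. Compound 4 `CCOC(=O)N1CCC(N2CCC[C@@H](NC(=O)c3cccc(F)c3)C2)CC1` has not yet been measured; it differs from compound 1 by 3-fluorophenyl in place of 4-methylphenyl on a carbonyl carbon. Among the compounds with values here, only the step from compound 1 to compound 3 bears on a change at this place, and it is unreadable, so no direction can be drawn from it; what the three measured compounds share is that each sits at a limit. Compound 4 is therefore expected to remain near the limit as well, with an estimated step that the limit leaves unreadable from compound 1 to compound 4. The estimate for compound 4 is 20000 nM, expected to fall between 8000 nM and 50000 nM.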

Compound 4, half-maximal effective concentration: > 10000 nM
Compound 4 was reported as a limit (the forecaster's own chance of this, stated with the estimate: 80%); the middle value is on the limit's open side.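

In this assay compound 4 gives > 10000 nM, which is a limit and not a number. No step among compound 1, compound 3 and compound 4 can be read, because all three sit at one boundary: the limit of > 10000 nM in this assay, at which 3 of the 4 values shown sit.

The compounds shown leave open whether any group on this carbonyl carbon would give a measurable value in this assay.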